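The source may hold more compounds than are shown below. What is called first, only, known or untested is meant among the compounds shown, and "the series" means these compounds.

Measured so far in a physicochemical assay for lipophilicity; a higher number here means a more lipophilic compound, a lower number a more polar compound
compound 1 `O=S(=O)(Nc1nccs1)c1ccc2c(c1)OCC[C@H]2c1ccc(C(F)(F)F)cc1-c1nccs1` gives 3.3
compound 2 `O=C1OCCN1c1cc(C(F)(F)F)ccc1[C@H]1CCOc2cc(S(=O)(=O)Nc3nccs3)ccc21` gives 2.1
compound 3 `Cn1nccc1-c1cc(C(F)(F)F)ccc1[C@H]1CCc2cc(S(=O)(=O)Nc3ncccn3)ccc21` gives 2.4

Compound 2 at 2.1 sits at the low end of these numbers together with compound 3 at 2.4, the two lying within the scatter of each other. Compound 1 at 3.3 stands higher than compound 2, beyond the scatter.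

The next entry is compound 4 `O=S(=O)(Nc1nccs1)c1ccc2c(c1)OCC[C@@H]2c1ccc(C(F)(F)F)cc1N1CCNCC1`, not yet measured in this assay. The structural change from compound 2 is piperazin-1-yl in place of 2-oxo-1,3-oxazolidin-3-yl on an aromatic carbon, with piperazin-1-yl in place of 2-oxo-1,3-oxazolidin-3-yl on an aromatic carbon.

Within the data shown here, no measured pair shows a comparable step, so its size is a judgement. A downward move beyond the scatter is expected, though a result within the scatter would not be surprising. The estimated step is a number 0.60 log units lower from compound 2 to compound 4 (beyond the scatter). The estimate for compound 4 is 1.5, with an expected range from 0.8 to 2.2.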

Compound 4, distribution coefficient: 1.4
Compound 4: middle estimate off by 0.10 log units, on the high side; measured number inside the range.
By their numbers in this assay, from the lowest: compound 4; then compounds 2 and 3 (each within the scatter of the next); then compound 1.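

In this assay, the position ortho to a large group and meta to a trifluoromethyl group now has its first readable step: piperazin-1-yl in place of 2-oxo-1,3-oxazolidin-3-yl gives a number 0.70 log units lower from compound 2 to compound 4 (beyond the scatter). The exchange keeps the heavy-atom count at 6 but alters the group's make-up, adding a hydrogen-bond donor, removing the double bond outside aromatic rings, and replacing a five-membered ring with a six-membered one, so the read-out at this position responds to a group of unchanged size by that count. No available evidence accounts for the step.

A single pair cannot separate the ring size, the ring atoms and the added donor. A morpholine ring, or a piperazine with a methyl on its second nitrogen, at the same carbon would help to divide these contributions.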